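A furan-2-yl swap on the carbonyl carbon

A few compounds are considered here, and "the series" means these few. Any claim that something is new, unique, unknown or untested is made for them only; others in the source may bear on it.

Measured in a functional assay on K562 cells (Homo sapiens) for cytotoxicity, read by MTT assay; a higher number here means a weaker inhibitor, a lower number a stronger inhibitor:
Compound 1 `COc1ccc(/C=C/C(=O)c2ccc(OC)c3c2OC(C)(C)C=C3)cc1OCC=C(C)C` gives > 10000 nM, which is a limit of the assay.
Compound 2 `COc1ccc(/C=C/C(=O)c2ccc(OC)c3c2OC(C)(C)C=C3)cc1OCCO` gives 8750 nM.
Compound 3 `COc1cccc(C(=O)Oc2cc(/C=C/C(=O)c3ccc(OC)c4c3OC(C)(C)C=C4)ccc2OC)c1` gives 790 nM.

Compound 3 stands lowest of the three, and its nearest neighbour is compound 2, as an 11-fold lower number from compound 2 to compound 3 (1.04 log units; beyond the scatter) shows. Compound 4 `COc1ccc(/C=C/C(=O)c2ccc(OC)c3c2OC(C)(C)C=C3)cc1OC(=O)c1ccco1` has furan-2-yl in place of 3-methoxyphenyl on a carbonyl carbon, and the difference counts as furan-2-yl in place of 3-methoxyphenyl on a carbonyl carbon. Two large measured steps bear on this, an at least 12-fold lower number from compound 1 to compound 3 (1.10 log units; beyond the scatter) and an 11-fold lower number from compound 2 to compound 3 (1.04 log units; beyond the scatter), and both bring in the (3-methoxyphenyl)carbonyl. Within the data shown here, compound 4 keeps the carbonyl, but no measured step changes the group on it, so a smaller shift towards a higher number is expected. The expected change is a 1.9-fold higher number from compound 3 to compound 4 (0.28 log units; within the scatter). For compound 4 the estimate in this assay is 1500 nM, with an expected range of 500 nM to 5000 nM.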

Compound 4, half-maximal inhibitory concentration: 450 nM
Estimate against measurement, compound 4: 3.3-fold (0.52 log units) above; measured number below the stated range.
By their numbers in this assay, from the lowest: compounds 4 and 3 (each within the scatter of the next); then compound 2. At a limit, above all of these: compound 1.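

In this assay, furan-2-yl on the carbonyl carbon and 3-methoxyphenyl there lie within the scatter of each other, a 1.8-fold lower number from compound 3 to compound 4 (0.24 log units; within the scatter), so the five-membered aromatic ring serves here as well as the six-membered one. The large step from 2-hydroxyethyl on the oxygen also holds with this second acyl group, a 19-fold lower number from compound 2 to compound 4 (1.29 log units; beyond the scatter). So does the step from 3-methylbut-2-en-1-yl, an at least 22-fold lower number from compound 1 to compound 4 (1.34 log units; beyond the scatter), whose size is only a floor, since it starts from a limit: the limit of > 10000 nM in this assay, at which 1 of the 4 values shown sits.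

The compounds shown leave open whether an aromatic ring on the carbonyl carbon is needed at all, which a methyl or a cyclohexyl there would test. They also leave open whether an amide linkage could stand in for the ester oxygen.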